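This account rests on a few compounds, and the source may have more. Where it says the series, first, only, none or still open, it means among the compounds named here.

In a physicochemical assay for lipophilicity, using the shake flask method, in phosphate buffer, measured as octanol-water partition, with a stated time of 2 h, at pH 7.4, tested at 1 uM (on this read-out higher numbers stand for higher lipophilicity and lower numbers for lower lipophilicity), compound 2 `O=C(c1ccc(-c2ccc(O[C@H]3O[C@H](CO)[C@@H](O)[C@H](O)[C@@H]3O)cc2)cc1)N1CCOCC1` gives 0.2, the lower of the two numbers, and compound 1 `CNC(=O)c1ccc(-c2ccc(O[C@H]3O[C@H](CO)[C@@H](O)[C@H](O)[C@@H]3O)cc2)cc1` gives 0.8. Compound 3 `N#Cc1ccc(-c2ccc(O[C@H]3O[C@H](CO)[C@@H](O)[C@H](O)[C@@H]3O)cc2)cc1` carries cyano in place of (morpholin-4-yl)carbonyl on an aromatic carbon. Among the compounds with values here, only one measured step bears on this, and only indirectly: a number 0.60 log units lower from compound 1 to compound 2 (beyond the scatter), a modest change on a carbonyl carbon, which went downward as the morpholin-4-yl group came in. Within the data shown here, no measured compound carries cyano. With the whole group leaving, an upward change larger than that step is expected, a number 1.30 log units higher from compound 2 to compound 3 (beyond the scatter). For compound 3 the estimated value is 1.5, with an expected range from 1 to 2.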

Compound 3, distribution coefficient: 1.4
Compound 3: middle estimate off by 0.10 log units, on the high side; low and high end bracket the measured number.
By their numbers in this assay, from the lowest: compound 2; then compound 1; then compound 3.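

In this assay, within the data shown here, the earlier compounds compared only two amides on the carbonyl carbon, whereas this change replaces the whole group on the aromatic carbon, para to a large group. Cyano in place of (morpholin-4-yl)carbonyl gives a number 1.20 log units higher from compound 2 to compound 3 (beyond the scatter), and cyano in place of methylcarbamoyl gives a number 0.60 log units higher from compound 1 to compound 3 (beyond the scatter), so the nitrile stands above both amides. No measurement shown explains these steps. Where a carboxylic acid, an amine or a lone methyl group at this position would fall remains open. So does whether the order of the three compounds would hold with a longer chain on the amide nitrogen.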